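From oxolan-3-yl to pyrimidin-4-yl on an oxygen

This account rests on a few compounds, and the source may have more. Where it says the series, first, only, none or still open, it means among the compounds named here.

Compound 1 `CC(C)(C)C#Cc1cc(N(C(=O)[C@H]2CC[C@H](C)CC2)[C@H]2CC[C@H](Oc3cccnc3)CC2)c(C(=O)O)s1`: > 20000 nM
Compound 2 `CC(C)(C)C#Cc1cc(N(C(=O)[C@H]2CC[C@H](C)CC2)[C@H]2CC[C@H](OC3CCOCC3)CC2)c(C(=O)O)s1`: > 20000 nM
Compound 3 `CC(C)(C)C#Cc1cc(N(C(=O)[C@H]2CC[C@H](C)CC2)[C@H]2CC[C@H](OC3CCOC3)CC2)c(C(=O)O)s1`: > 20000 nM

In an ADME assay on MT4 cells (Homo sapiens) for cytotoxicity, with a stated time of 5 days (on this read-out lower numbers stand for higher toxicity in this test and higher numbers for lower toxicity in this test), compound 3 gives > 20000 nM, which is a limit and not a number. The three measured compounds share one mark: the limit of > 20000 nM in this assay, at which 3 of the 3 values shown sit.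

Compound 4 `CC(C)(C)C#Cc1cc(N(C(=O)[C@H]2CC[C@H](C)CC2)[C@H]2CC[C@H](Oc3ccncn3)CC2)c(C(=O)O)s1` has pyrimidin-4-yl in place of oxolan-3-yl on an oxygen on a saturated carbon.

Three measured steps change the group at this same place: a step that the two limits leave unreadable from compound 1 to compound 2, a step that the two limits leave unreadable from compound 1 to compound 3 and a step that the two limits leave unreadable from compound 2 to compound 3. None of them has a readable size. Compound 1, which also carries an aromatic ring on that oxygen, gives > 20000 nM, again a limit. On this evidence, no step beyond the scatter is expected in this assay, in either direction. The expected step is a step that the limit leaves unreadable from compound 3 to compound 4. Compound 4 is estimated at 25000 nM, with an expected range from 12000 nM to 50000 nM.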

Compound 4, half-maximal cytotoxic concentration: > 20000 nM
Compound 4: a limit, no number; the forecaster's own chance of this, stated with the estimate: 90%; the middle value lies beyond the limit too.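

Compound 4 gives > 20000 nM in this assay, which is a limit and not a number. Among the compounds shown here, no step from compound 1, compound 2 or compound 3 to compound 4 can be read, because all four share one mark: the limit of > 20000 nM in this assay, at which 4 of the 4 values shown sit. The compounds shown leave open whether the group on this oxygen changes the half-maximal cytotoxic concentration at all.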